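A few compounds are considered here, and "the series" means these few. Any claim that something is new, unique, unknown or untested is made for them only; others in the source may bear on it.

Series notes. Compound 1 `Cc1nc(-c2ccccc2F)c(C(=O)N2CCN(c3cccc(Cl)c3)CC2)o1` gives 39.4 nM in a functional assay on HL-60 cells (Homo sapiens) for inhibition, read by MTT assay, with a stated time of 72 h; a higher number here means a weaker inhibitor, a lower number a stronger inhibitor. Compound 2 `COc1cccc(-c2nc(C)oc2C(=O)N2CCN(c3cccc(Cl)c3)CC2)c1` in this assay gives "not active" (no number reported), so no number stands for compound 2, and nothing beyond the two readings can be said of the pair. Compound 3 `COc1cc(-c2nc(C)oc2C(=O)N2CCN(c3cccc(Cl)c3)CC2)ccc1O` differs from compound 2 by hydroxy in place of hydrogen on an aromatic carbon. For the measured compounds named here, with no number for compound 2 and no measured step for this change, the size and direction of the move in this assay on going to compound 3 cannot be fixed from the data. Compound 3 is estimated at 5000 nM, with a range from 500 nM to 50000 nM, and a fair chance that only a limit is reported.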

Compound 3, half-maximal inhibitory concentration: 85.9 nM
For compound 3 the middle estimate is 58-fold (1.76 log units) above the measured one; measured number below the stated range.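

In this assay, 4-hydroxy-3-methoxyphenyl in place of 2-fluorophenyl gives a 2.2-fold higher number from compound 1 to compound 3 (0.34 log units; beyond the scatter), so a second aryl group at this position carries a number. Hydroxy in place of hydrogen leaves a pair with a number on one side only, as compound 2 reads "not active" (no number reported), and the step to compound 3 cannot be read. No measurement bearing on this result is available.

Open, from the compounds shown here alone, is whether 4-hydroxyphenyl, without the methoxy group, would hold a number in this assay. Also open, going by these compounds, is how an amine or a carboxylic acid would read in the place of hydroxy.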